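A few compounds are considered here, and "the series" means these few. Any claim that something is new, unique, unknown or untested is made for them only; others in the source may bear on it.

Measured in a functional assay on DU-145 cells (Homo sapiens) for inhibition, read by trypan blue exclusion, with a stated time of 96 h; a higher number here means a weaker inhibitor of growth, a lower number a stronger inhibitor of growth:
- compound 1 `Cc1ccc(S/C(=C/c2ccc(N(C)C)cc2)C(=O)c2ccc(Cl)cc2)cc1`: > 100000 nM (a limit of the assay)
- compound 2 `Cc1ccc(S/C(=C/c2ccc(Oc3ccccc3)cc2)C(=O)c2ccc(Cl)cc2)cc1`: 10000 nM
- compound 3 `Cc1ccc(S/C(=C/c2ccc(-c3ccccc3)cc2)C(=O)c2ccc(Cl)cc2)cc1`: 50000 nM

Compound 3 at 50000 nM has the higher of the two exact numbers, and compound 2 lies lower at 10000 nM. Compound 1 gives only a limit, > 100000 nM.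

Compound 4 `Cc1ccc(S/C(=C/c2ccc(Cl)cc2)C(=O)c2ccc(Cl)cc2)cc1` has chloro in place of phenyl on an aromatic carbon, para to a large group: chloro in place of phenyl on an aromatic carbon.

For the measured compounds named here, no measured compound shows this exact exchange, but the three measured steps all change the group at this place. They are an at least 10-fold lower number from compound 1 to compound 2 (1.00 log units; beyond the scatter), an at least 2.0-fold lower number from compound 1 to compound 3 (0.30 log units; that floor lies within the scatter) and a 5.0-fold higher number from compound 2 to compound 3 (0.70 log units; beyond the scatter). The two steps from compound 1 have only floors as sizes, so the step between compound 2 and compound 3 is the firmest guide to size, and it is modest. None of them tells the direction for chloro. A modest fall in the number is expected, mainly because compound 3 stands above compound 2 at 10000 nM, but this direction is tentative and the range is kept wide.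

The expected change is a 2.8-fold lower number from compound 3 to compound 4 (0.44 log units; beyond the scatter).

For compound 4 the estimated value is 18000 nM, with an expected range from 4000 nM to 80000 nM.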

Compound 4, concentration for 50% growth inhibition: 10000 nM
Compound 4: the middle estimate sits 1.8-fold (0.26 log units) above what was measured, within the range that was stated.
By their numbers in this assay, from the lowest: compounds 2 and 4 (each within the scatter of the next); then compound 3. At a limit, above all of these: compound 1.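

In this assay, chloro in place of phenyl on this aromatic carbon gives a 5.0-fold lower number from compound 3 to compound 4 (0.70 log units; beyond the scatter), so the phenyl ring is not needed here for the lower number. Chloro in place of phenoxy gives no change at the digits printed from compound 2 to compound 4 (within the scatter), which places these two very different groups at one level and leaves phenyl apart from them, a contrast that a comparison of phenoxy and phenyl alone could not reveal. Chloro in place of dimethylamino gives an at least 10-fold lower number from compound 1 to compound 4 (1.00 log units; beyond the scatter), a size that is only a floor and matches the floor seen for phenoxy: the limit of > 100000 nM in this assay, at which 1 of the 4 values shown sits.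

Still open, on these data alone, is whether other groups on this carbon, such as hydrogen, fluoro, methoxy or a carboxylic acid, would fall with chloro and phenoxy or would stand with phenyl or dimethylamino, and four groups are too few to state any trend at this place. Also open, as far as these compounds go, is whether the same exchange of phenyl for chloro holds when other parts of the shared core change, as all four compounds keep the rest of that core fixed.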